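This account rests on a few compounds, and the source may have more. Where it says the series, first, only, none or still open, it means among the compounds named here.

Measured compounds:
- compound 1 `C=CCn1c(=O)/c(=C\c2cc(Br)ccc2F)[nH]c(=O)/c1=C\c1ccccc1OC`: "not active" (no number reported)
- compound 2 `C=CCn1c(=O)/c(=C\c2cccc(Br)c2)[nH]c(=O)/c1=C\c1ccccc1OC`: "not active" (no number reported)
- compound 3 `C=CCn1c(=O)/c(=C\c2ccccc2C(F)(F)F)[nH]c(=O)/c1=C\c1ccccc1OC`: 14500 nM

In a functional assay on NCI-H1975 cells (Homo sapiens) for cytotoxicity, read by CCK-8 assay, with a stated time of 72 h (on this read-out higher numbers stand for weaker inhibition and lower numbers for stronger inhibition), compound 1 is reported as "not active" (no number reported) and compound 2 as "not active" (no number reported), neither with a number. Compound 3 gives 14500 nM in this assay and so holds the only number in the series; it is a weak value, and no step between two numbered compounds can be drawn from what is shown.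

Compound 4 `C=CCn1c(=O)/c(=C\c2ccc(C)cc2)[nH]c(=O)/c1=C\c1ccccc1OC` differs from compound 3 by 4-methylphenyl in place of 2-(trifluoromethyl)phenyl on a double-bonded chain carbon bound to an aromatic carbon. With the two bromine-bearing analogues inactive and compound 3 weak, the shared core appears to give only weak inhibition in this assay regardless of the aryl group on the double-bonded chain carbon, so no step beyond the usual scatter is expected in either direction. Compound 4 is therefore expected to stay in the weak range, with a real chance that this assay reports it as not active. The expected step of a 1.4-fold higher number from compound 3 to compound 4 (0.14 log units; within the scatter) is small. The estimate for compound 4 in this assay is 20000 nM, between 5000 nM and 80000 nM.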

Compound 4, half-maximal inhibitory concentration: "not active" (no number reported)
Compound 4 has no reported number here; the estimate stays without a comparison.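

In this assay, among the compounds shown here, compound 4 is reported as "not active" (no number reported) and thus gives no number, so no step from compound 3 at 14500 nM can be read. The compounds shown leave open whether any aryl group at this place on the shared core gives stronger inhibition. No measurement shown accounts for this result.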